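Swapping Methoxy for Trifluoromethyl in a Cytotoxicity Series

A few compounds are considered here, and "the series" means these few. Any claim that something is new, unique, unknown or untested is made for them only; others in the source may bear on it.

Compound 1 `COc1ccc(C(=O)c2cc(OC)c(OC)c(OC)c2)cc1N` and compound 2 `COc1ccc(/C=C/C(=O)Nc2cc(C(=O)c3cc(OC)c(OC)c(OC)c3)ccc2OC)cc1` were both tested in a functional assay on HT-29 cells (Homo sapiens) for cytotoxicity, read by MTT assay, with a stated time of 72 h; on this read-out higher numbers stand for weaker inhibition and lower numbers for stronger inhibition. In that assay compound 1 gives 50 nM, while compound 2 gives 5010 nM. Among the compounds with values here, compound 2 thus stands at the highest of the two numbers, and its only neighbour, compound 1, lies far below it, a gap well beyond the usual scatter of repeated measurements. Compound 3 `COc1ccc(C(=O)c2cc(OC)c(OC)c(OC)c2)cc1NC(=O)/C=C/c1ccc(C(F)(F)F)cc1` has not yet been measured in this assay. It differs from compound 2 in one place: trifluoromethyl in place of methoxy on an aromatic carbon, sitting on an aromatic carbon of a six-membered aromatic ring of carbon only, para to a large group. Within the data shown here, no measured pair of compounds shows the effect of this particular change, so no step can be read directly from the data. The expectation is that the number for compound 3 in this assay stays close to that of compound 2, with the step of a 1.4-fold lower number from compound 2 to compound 3 (0.16 log units; within the scatter) small and quite possibly within the scatter. Compound 3 is therefore estimated at 3500 nM, with a range from 900 nM to 14000 nM.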

Compound 3, half-maximal inhibitory concentration: 1600 nM
For compound 3 the middle estimate is 2.2-fold (0.34 log units) above the measured one; low and high end bracket the measured number.
By their numbers in this assay, from the lowest: compound 1; then compound 3; then compound 2.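

In this assay, trifluoromethyl in place of methoxy, on an aromatic carbon of a six-membered aromatic ring of carbon only and para to a large group, gives a 3.1-fold lower number from compound 2 to compound 3 (0.50 log units; beyond the scatter), so this position responds to the change by more than repeated measurements would scatter. Within the data shown here, the earlier compounds held no pair differing at this place, which makes this the first direct reading of the position, and the step is modest and rests on this single pair. Nothing at hand bears on why the number moves with this change.

The compounds shown leave open whether other groups at this place, such as a chlorine atom, a nitrile, an amine or a carboxylic acid, would carry the number further down, leave it unchanged or push it up, and so whether trifluoromethyl stands out or simply belongs to a wider trend. They also leave open whether the same swap would give a step of similar size elsewhere on this ring, or on a longer chain joining this ring to the shared core.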